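Adding a chloro to the phenyl arm of compound 3

The source may report more compounds than this note shows. Statements on the series, on what has been measured and on what is new or still open speak of the compounds shown alone.

Of the compounds shown here, three of one shared core have been measured so far. Compound 1 `COc1cc(/C=C/C(=O)c2cccc(-n3cc(-c4ccc(Cl)cc4)[nH]c3=O)c2)cc(OC)c1OC` carries a chloro on its phenyl arm and a trimethoxyphenyl at the far end of the chain; in a functional assay on M14 cells (Homo sapiens) for inhibition (a higher number here means a weaker inhibitor of growth, a lower number a stronger inhibitor of growth), compound 1 gives 4360 nM. Compound 2 `COc1cc(/C=C/C(=O)c2cccc(-n3cc(-c4ccccc4)[nH]c3=O)c2)ccc1O` gives 2610 nM, and compound 3 `O=C(/C=C/c1cccc(O)c1)c1cccc(-n2cc(-c3ccccc3)[nH]c2=O)c1` gives 4530 nM. The only single-point step shown, a 1.7-fold higher number from compound 2 to compound 3 (0.24 log units; within the scatter), changes the far end of the chain, not the phenyl arm. Compound 3 sits at the high end of the three numbers, yet within the scatter of both compound 1 and compound 2.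

Compound 4 `O=C(/C=C/c1cccc(O)c1)c1cccc(-n2cc(-c3ccc(Cl)cc3)[nH]c2=O)c1` differs from compound 3 by chloro in place of hydrogen on an aromatic carbon, read one bond further out as phenyl to 4-chlorophenyl. Within the data shown here, no measured step isolates this change; compound 1 and compound 3, which differ here and at the chain end, show values within the scatter of each other. Compound 4 is therefore expected to move a 1.1-fold lower number from compound 3 to compound 4 (0.05 log units; within the scatter), no further than the scatter. The estimate for compound 4 is 4000 nM, between 1800 nM and 9000 nM.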

Compound 4, concentration for 50% growth inhibition: 2010 nM
Compound 4: middle estimate off by 2.0-fold (0.30 log units), on the high side, and the stated range covers the measured number.
By their numbers in this assay, from the lowest: compounds 4, 2, 1 and 3 (each within the scatter of the next, the first and the last beyond it).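

In this assay, the step from phenyl to 4-chlorophenyl gives a 2.3-fold lower number from compound 3 to compound 4 (0.35 log units; beyond the scatter), a modest change. This is the first step shown that alters only the phenyl arm, with the 3-hydroxyphenyl at the chain end held fixed. Compound 1 also has the chloro but carries a different chain end, so it could not isolate this change; here, a single chlorine atom on an aromatic carbon, para to a large group, is enough to lower the number beyond the scatter, and no measurement here bears on why.

The compounds shown leave open whether the chloro acts the same way with the 4-hydroxy-3-methoxyphenyl chain end of compound 2. They also leave open whether a fluoro, a bromo or a methyl in the same place would do the same.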